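Swapping the Group on a Weaker Inhibitor

The compounds below may be only part of what the source reports. "The series", "measured", "known", "first", "only" and "open" are said of these compounds alone.

In a functional assay on B16-F0 cells (Mus musculus) for inhibition, read by CCK-8 assay, with a stated time of 48 h (a lower number here means a stronger inhibitor, a higher number a weaker inhibitor), compound 1 (`COc1cc(-c2ccnc3cc(-c4ccc5cc[nH]c5c4)nn23)cc(OC)c1OC`) gives 55 nM, while compound 2 (`COc1cc(-c2ccnc3cc(-c4ccc5cnn(C)c5c4)nn23)cc(OC)c1OC`) gives 1000 nM. That is the higher of the two numbers, which makes compound 2 the weaker inhibitor. Compound 3 (`COc1ccc(-c2cc3nccc(-c4cc(OC)c(OC)c(OC)c4)n3n2)cc1F`) keeps the shared core and changes the same group: 3-fluoro-4-methoxyphenyl in place of 1-methyl-1H-indazol-6-yl on an aromatic carbon. For the measured compounds named here, the only measured step bearing on this is an 18-fold higher number from compound 1 to compound 2 (1.26 log units; beyond the scatter). It is a large step, and the two compounds differ in the group at this same place. Going by the values given here, no measured compound carries the 3-fluoro-4-methoxyphenyl group, so the size of the next step remains uncertain. Compound 1, at 55 nM, shows that a group here can give far stronger inhibition than compound 2 does. The expected outcome in this assay is a 5.0-fold lower number from compound 2 to compound 3 (0.70 log units; beyond the scatter), recovering only part of that gap. For compound 3, the estimated value is 200 nM, with an expected range of 50 nM to 800 nM.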

Compound 3, half-maximal inhibitory concentration: 3950 nM
Compound 3: the middle estimate sits 20-fold (1.30 log units) below what was measured, and the stated range ends below it.
By their numbers in this assay, from the lowest: compound 1; then compound 2; then compound 3.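

In this assay, putting 3-fluoro-4-methoxyphenyl in place of 1-methyl-1H-indazol-6-yl brings a 4.0-fold higher number from compound 2 to compound 3 (0.60 log units; beyond the scatter), so this change weakens inhibition further rather than recovering any of the strength seen with compound 1. Set against the 1H-indol-6-yl group, the same 3-fluoro-4-methoxyphenyl group brings a 72-fold higher number from compound 1 to compound 3 (1.86 log units; beyond the scatter), which makes compound 3 the weakest of the three and leaves compound 1 clearly ahead at this position. No evidence here explains these differences.

As far as these compounds go, compound 3 carries its fluorine and methoxy together, so the separate contribution of each remains open, and a plain phenyl ring would help to separate them. A 1-methyl-1H-indol-6-yl group could likewise show how much of the gap between compound 1 and compound 2 follows the methyl on nitrogen.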